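Aromatic Ring Replaces Isopentyl Chain in Compound 4

A few compounds are considered here, and "the series" means these few. Any claim that something is new, unique, unknown or untested is made for them only; others in the source may bear on it.

Three amide-type compounds sharing one core have been measured in an assay on LtK cells with ATP-sensitive inward rectifier potassium channel 11 (Homo sapiens) as the target; a lower number here means that less compound is needed, a higher number that more compound is needed for the effect. Compound 2, `CC(C)CCC(=O)Nc1c(C(O)(C(F)(F)F)C(F)(F)F)ccc2ccccc12`, gives 49 nM, the lowest number of the three. Compound 1, `CCC(CC)C(=O)Nc1c(C(O)(C(F)(F)F)C(F)(F)F)ccc2ccccc12`, gives 4340 nM, and compound 3, `O=C(NCCCCCCCl)Nc1c(C(O)(C(F)(F)F)C(F)(F)F)ccc2ccccc12`, gives 4840 nM. The steps between them are large: an 89-fold lower number from compound 1 to compound 2 (1.95 log units; beyond the scatter), and a 99-fold higher number from compound 2 to compound 3 (1.99 log units; beyond the scatter), whereas a 1.1-fold higher number from compound 1 to compound 3 (0.05 log units; within the scatter).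

The next compound, compound 4, `Cc1ccccc1C(=O)Nc1c(C(O)(C(F)(F)F)C(F)(F)F)ccc2ccccc12`, differs from compound 2 in one place: 2-methylphenyl in place of isopentyl on a carbonyl carbon. Both measured steps that change this same position, from compound 1 to compound 2 and from compound 2 to compound 3, moved this assay by a large amount, and compound 2 sits at the favourable end of both. Among the measured compounds shown here, the group on the carbonyl carbon therefore governs the read-out strongly, and compound 2 holds the only favourable group seen so far. The exchange of an isopentyl chain for a 2-methylphenyl ring is a larger change in composition than either measured one. A step towards a higher number is expected, though its size is uncertain since no aromatic group at this position has been measured. Compound 4 is expected to give 1500 nM, with a range from 200 nM to 8000 nM, which corresponds to an expected step of a 31-fold higher number from compound 2 to compound 4 (1.49 log units; beyond the scatter).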

Compound 4, half-maximal effective concentration: 5550 nM
Compound 4: middle estimate off by 3.7-fold (0.57 log units), on the low side; the range from low to high includes it.
By their numbers in this assay, from the lowest: compound 2; then compounds 1, 3 and 4 (each within the scatter of the next).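

In this assay, 2-methylphenyl, the first aromatic ring seen on this carbonyl carbon, gives no separation from the two groups that had already given high numbers, with a 1.3-fold higher number from compound 1 to compound 4 (0.11 log units; within the scatter) and a 1.1-fold higher number from compound 3 to compound 4 (0.06 log units; within the scatter). Set against isopentyl, the same ring gives a 110-fold higher number from compound 2 to compound 4 (2.05 log units; beyond the scatter), so compound 2 now stands apart from three compounds that carry a branched chain, a chlorinated chain on an amino link and an aromatic ring, and that lie within the scatter of one another. Nothing available bears on what lies behind this result.

The compounds shown leave open how narrowly the low number is tied to isopentyl, as a straight pentyl chain, a shorter isobutyl chain or a benzyl group on this carbonyl carbon could fall with compound 2 or with the other three. They also leave open whether the methyl of the ring has any bearing on the read-out, since an unsubstituted phenyl ring or a 4-methylphenyl ring does not appear among them.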